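A few compounds are considered here, and "the series" means these few. Any claim that something is new, unique, unknown or untested is made for them only; others in the source may bear on it.

Compound 1 `COc1ccc(-c2nc(C)c(C(=O)CSc3nc(N)c(C#N)c(-c4ccc(Cl)cc4)n3)s2)cc1`, compound 2 `COc1ccc(-c2nc(C)c(C(=O)CSc3nc(-c4ccc(OC)cc4)c(C#N)c(=O)[nH]3)s2)cc1` and compound 3 `COc1ccc(-c2nc(C)c(C(=O)CSc3nc(-c4ccc(OC)c(OC)c4)c(C#N)c(=O)[nH]3)s2)cc1` were all tested in a functional assay on U-87MG ATCC cells for antiproliferative activity against U-87 MG (Homo sapiens), read by MTT assay, with a stated time of 48 h, tested at 10 uM; a higher number here means a weaker effect of the compound at the concentration tested, a lower number a stronger effect. Compound 1 gives 44%, compound 2 gives 80.3%, and compound 3 gives 57.6%. Among these three, compound 1 has the lowest number, and its gaps to compound 3 and to compound 2 both lie beyond the scatter. Compound 2 and compound 3 differ in one place hydrogen in place of methoxy on an aromatic carbon and that change made a step of a number 22.7 percentage points higher from compound 3 to compound 2 (beyond the scatter). Compound 4 `Cc1nc(-c2ccccc2)sc1C(=O)CSc1nc(N)c(C#N)c(-c2ccc(Cl)cc2)n1` has not been measured; it differs from compound 1 in one place (hydrogen in place of methoxy on an aromatic carbon). The difference between the core of compound 1 and the core of compound 3 is not broken down here. The two changes are the same kind of change but not the same: in compound 3 the methoxy that leaves sits ortho to a methoxy group and meta to a large group, whereas in compound 1 it sits para to a large group. Because the same kind of change produced a number 22.7 percentage points higher from compound 3 to compound 2 (beyond the scatter), for compound 4 the expected step is a number 14 percentage points higher from compound 1 to compound 4 (beyond the scatter), with the unlike surroundings and the unbroken-down core difference leaving this uncertain. Compound 4 is therefore estimated at 58%, between 40% and 78%.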

Compound 4, a percentage reported as activity, at one concentration (the size of the read-out at that concentration, not a potency): 58.8%
Compound 4: middle estimate off by 0.8 percentage points, on the low side; the range from low to high includes it.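

In this assay, going from 4-methoxyphenyl to phenyl gives a number 14.8 percentage points higher from compound 1 to compound 4 (beyond the scatter), so removing the methoxy leaves a weaker effect at the concentration tested. Set beside the earlier case, the same change raises the number on both cores, and the size of the rise does not measurably depend on the core: the same change on two cores in this assay, a number 22.7 percentage points higher (beyond the scatter) from compound 3 to compound 2 and a number 14.8 percentage points higher (beyond the scatter) from compound 1 to compound 4, 7.9 percentage points apart, within the scatter of two such steps. Within the data shown here, these are only two pairs, however, with the methoxy leaving a different setting in each, so they support carrying this change between these two cores but establish no rule for the whole series and do not explain why the number rises.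

The compounds shown leave open whether a different group at this place on the aromatic ring, such as an ethoxy group or a carboxylic acid, would give a stronger or weaker effect than methoxy. They also leave open whether the same step would appear at another concentration or in other cell types.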